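The source may report more compounds than this note shows. Statements on the series, on what has been measured and on what is new or still open speak of the compounds shown alone.

Series notes. The shared core of compound 1 `Cc1ccc(NC(=O)N/N=C/c2ccc3ccccc3n2)cc1` carries a urea linkage; in a functional assay on SGC-7901 cells (Homo sapiens) for antiproliferative activity, read by sulforhodamine B assay, with a stated time of 72 h (on this read-out lower numbers stand for stronger inhibition and higher numbers for weaker inhibition), compound 1 gives only a limit, > 100000 nM. Compound 2 `Fc1ccccc1NC(=S)N/N=C/c1ccc2ccccc2n1` is the thiourea counterpart on the same core; in this assay compound 2 likewise returns a limit, > 100000 nM. For the measured compounds named here, compound 3 `CN(C)C(=S)N/N=C/c1cc2cccnc2s1`, built on a different core with the thiourea carrying two methyl groups, is the single value that is a number: in this assay compound 3 gives 21400 nM. Compound 2 therefore stands at the limit of > 100000 nM in this assay, at which 2 of the 3 values shown sit, with no number of its own that could be ranked against compound 3 beyond the limit itself.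

Compound 4 `COc1ccc(NC(=S)N/N=C/c2ccc3ccccc3n2)cc1` has not yet been measured. Its difference from compound 2 is 4-methoxyphenyl in place of 2-fluorophenyl on an amide-type nitrogen. Going by the values given here, no measured pair differs in a single place, so no step size has been measured; both compounds sharing the core of compound 2 sit at the limit in this assay, and a change confined to the group on the amide-type nitrogen is expected to shift the value by no more than the scatter, direction unknown. The step from compound 2 to compound 4 is expected to be an at least 1.4-fold lower number from compound 2 to compound 4 (0.15 log units; that floor lies within the scatter). For compound 4 in this assay the estimate is 70000 nM, within 20000 nM to 200000 nM, with a fair chance that only a limit is returned again.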

Compound 4, half-maximal inhibitory concentration: 89600 nM
The estimate for compound 4 lay 1.3-fold (0.11 log units) below the measured number; low and high end bracket the measured number.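

For the compounds shown here, compound 4 gives the only number among the compounds on the shared core of compound 2, so a group on an amide-type nitrogen whose other neighbour is the thiocarbonyl carbon can bring that core into the measurable range of this assay. Going by these compounds alone, the change of 2-fluorophenyl to 4-methoxyphenyl at this position also supplies the first readable step, an at least 1.1-fold lower number from compound 2 to compound 4 (0.04 log units; that floor lies within the scatter), and that step is only a floor and does not establish a real difference between the two groups. From the compounds shown here alone, the true size of the step stays unknown, since the value for compound 2 is a limit and not a number: the limit of > 100000 nM in this assay, at which 2 of the 4 values shown sit.

The compounds shown leave open whether the 4-methoxyphenyl group itself matters or whether other groups at this position would give similar numbers in this assay, and no single-place pair isolates the thiocarbonyl from the carbonyl or either core from the other. Also open, going by these compounds, is how an amine such as piperidine, a carboxylic acid or a longer alkyl chain on this amide-type nitrogen would read on the same core.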